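A Methyl Added to a Compound Already at the Limit

The compounds below may be only part of what the source reports. "The series", "measured", "known", "first", "only" and "open" are said of these compounds alone.

This account follows a pair of sulfonylamidines bearing a chromane amide. Compound 1 `Cc1ccc2c(c1)S(=O)(=O)N=C(C(=O)NC1CC(C)(C)Oc3ccc(Br)cc31)N2` and compound 2 `CC1(C)CC(NC(=O)C2=NS(=O)(=O)c3ccccc3N2)c2cc([N+](=O)[O-])ccc2O1` were both tested in a functional assay on aorta (Rattus norvegicus, strain Wistar) for inhibition; a higher number here means that more compound is needed for the effect, a lower number that less compound is needed. Compound 1 gives only a limit there, namely > 30000 nM, and not a number. Compound 2 likewise reaches only the limit of > 30000 nM in this assay. Within the data shown here, compound 2 therefore stands at no measured position on a scale of numbers at all; it sits at the limit, as does the single other value shown, and that is stated in the limit of > 30000 nM in this assay, at which 2 of the 2 values shown sit.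

Compound 3 `Cc1ccc2c(c1)S(=O)(=O)N=C(C(=O)NC1CC(C)(C)Oc3ccc([N+](=O)[O-])cc31)N2` has not yet been measured in this assay. It differs from compound 2 by methyl in place of hydrogen on an aromatic carbon. The same methyl is present in compound 1, which also returns only a limit in this assay. Among the measured compounds shown here, no measured step is available for this change, so no direction can be read from the data. Compound 3 is therefore expected to sit at or near the limit, with the step of a number no higher from compound 2 to compound 3 (the limit leaves the size open) estimated as none beyond the scatter. For compound 3 the estimated value is 30000 nM, within a range from 10000 nM to 100000 nM.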

Compound 3, half-maximal effective concentration: > 30000 nM
Compound 3: only a limit was reported; the forecaster's own chance of this, stated with the estimate: 80%; the middle value lies on the limit itself.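

In this assay compound 3 gives > 30000 nM, which is a limit and not a number. Among these compounds, no step from compound 1 or compound 2 to compound 3 can be read, because all three compounds stand at the same limit: the limit of > 30000 nM in this assay, at which 3 of the 3 values shown sit. The compounds shown leave open whether methyl in place of hydrogen, or nitro in place of bromo, changes the concentration needed in this assay.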